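Nitro for Hydroxy on the Aryl Ketone of Compound 3

The source may hold more compounds than are shown below. What is called first, only, known or untested is meant among the compounds shown, and "the series" means these compounds.

Three compounds have been measured in a functional assay (aorta) with Rattus norvegicus as the target; a lower number here means a less potent compound, a higher number a more potent compound, by a factor of ten per unit of this negative logarithm:

compound 1, `CCC(=O)c1ccc2c(c1)C(n1ccccc1=O)=CC(C)(C)O2`, gives 6.63
compound 2, `CC1(C)C=C(n2ccccc2=O)c2cc(C(=O)c3ccccc3)ccc2O1`, gives 6.61
compound 3, `CC1(C)C=C(n2ccccc2=O)c2cc(C(=O)c3ccc(O)cc3)ccc2O1`, gives 6.65

The three numbers sit close together. The step of a number 0.02 log units lower from compound 1 to compound 2 (within the scatter) replaces ethyl with phenyl on the carbonyl carbon, and the step of a number 0.02 log units higher from compound 1 to compound 3 (within the scatter) replaces ethyl with 4-hydroxyphenyl there; the step of a number 0.04 log units higher from compound 2 to compound 3 (within the scatter) puts hydroxy in place of hydrogen on the aromatic carbon. None of these moves the read-out beyond the scatter, so compound 3 stands level with both of its neighbours.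

Compound 4, `CC1(C)C=C(n2ccccc2=O)c2cc(C(=O)c3ccc([N+](=O)[O-])cc3)ccc2O1`, carries the change (nitro in place of hydroxy on an aromatic carbon). The step that bears most directly on it is a number 0.04 log units higher from compound 2 to compound 3 (within the scatter), which shows that adding a group at this same aromatic carbon left the read-out unchanged, and the two carbonyl-carbon steps tell the same story. The expectation for compound 4 is therefore a step of a number 0.05 log units lower from compound 3 to compound 4 (within the scatter), none beyond the scatter. Compound 4 is estimated at 6.6, with a range from 6.1 to 7.1.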

Compound 4, logarithm of the reciprocal of the active concentration, log(1/C): 6.2
Estimate against measurement, compound 4: 0.40 log units above, and the stated range covers the measured number.
By their numbers in this assay, from the lowest: compound 4; then compounds 2, 1 and 3 (each within the scatter of the next).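

At this place on the six-membered aromatic ring, hydrogen and hydroxy had given no separable numbers, but nitro does separate in this assay with a number 0.45 log units lower from compound 3 to compound 4 (beyond the scatter) and a number 0.41 log units lower from compound 2 to compound 4 (beyond the scatter) in the two direct comparisons. The same holds with the whole 4-nitrophenyl group in place of ethyl on the carbonyl carbon, where the result is a number 0.43 log units lower from compound 1 to compound 4 (beyond the scatter) and compound 4 alone stands apart from the other three. No measurement here accounts for this lower number, so its cause remains unknown.

The compounds shown leave open whether the lower number belongs to nitro alone or would also appear with another group at this place, such as an amine, a nitrile or a carboxylic acid. They also leave open what nitro would do elsewhere on this ring.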